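The source may hold more compounds than are shown below. What is called first, only, known or untested is meant among the compounds shown, and "the series" means these compounds.

Measured so far in a functional assay on HeLa cells (Homo sapiens) for cytotoxicity, read by MTT assay, with a stated time of 48 h; on this read-out lower numbers stand for stronger inhibition and higher numbers for weaker inhibition:
compound 1, `COC(=O)c1c(-c2cc3ccccc3oc2=O)nn(-c2cccc(C)c2)c1C(=O)OC`: 45000 nM
compound 2, `COC(=O)c1c(-c2cc3ccccc3oc2=O)nn(-c2cccc(F)c2)c1C(=O)OC`: 76000 nM

Compound 2 gives the higher of the two numbers, but the step of a 1.7-fold higher number from compound 1 to compound 2 (0.23 log units; within the scatter) lies within the scatter, so the two compounds cannot be told apart on this read-out. Going by the values given here, the only structural change seen so far is fluoro in place of methyl on an aromatic carbon of the ring that sits on the nitrogen of the shared core.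

Compound 3, `COC(=O)c1c(-c2cc3ccccc3oc2=O)nn(-c2ccc(Br)cc2)c1C(=O)OC`, has not been measured. It differs from compound 2 by 4-bromophenyl in place of 3-fluorophenyl on an aromatic nitrogen. Among the compounds with values here, no measured step bears on a bromo substituent or on a substituent in the 4-position of this ring; the one step at hand, methyl to fluoro on the same ring, stayed within the scatter. With nothing pointing either way, no step beyond the scatter is expected in this assay, and the estimate places compound 3 close to compound 2. The expected step of a 1.3-fold lower number from compound 2 to compound 3 (0.10 log units; within the scatter) is therefore nominal. Compound 3 is expected to give 60000 nM, within 25000 nM to 150000 nM.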

Compound 3, half-maximal inhibitory concentration: 120000 nM
For compound 3 the middle estimate is 2.0-fold (0.30 log units) below the measured one; measured number inside the range.
By their numbers in this assay, from the lowest: compounds 1, 2 and 3 (each within the scatter of the next, the first and the last beyond it).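

Working notes on the aryl group on the aromatic nitrogen: in this assay this position now gives its first step beyond the scatter, a 2.7-fold higher number from compound 1 to compound 3 (0.43 log units; beyond the scatter), though the step is modest. The other new step, a 1.6-fold higher number from compound 2 to compound 3 (0.20 log units; within the scatter), stays within the scatter, so this position shows a measurable spread only between the outer pair of the three compounds, and the pair joined by this smaller step cannot be told apart. The larger step changes both the substituent and its number in the group name, from 3-methylphenyl to 4-bromophenyl, so these two changes cannot be separated, and nothing at hand offers an explanation for either step.

As far as these compounds go, whether 3-bromophenyl or 4-methylphenyl would separate the substituent from its ring position remains open. Also open, from the compounds shown here alone, is whether an amine or a carboxylic acid on this phenyl ring, or a carboxylic acid in place of a methoxycarbonyl group on the shared core, would shift the number by more than these steps.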